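Growth inhibition on A2780 cells: a substituted benzylamine step

A few compounds are considered here, and "the series" means these few. Any claim that something is new, unique, unknown or untested is made for them only; others in the source may bear on it.

Compound 1, `O=S(=O)(NCCCNCc1cccc2ccccc12)c1cc(C(F)(F)F)cc(C(F)(F)F)c1`: 3100 nM
Compound 2, `O=S(=O)(NCCCNCc1ccc(Cl)cc1)c1cc(C(F)(F)F)cc(C(F)(F)F)c1`: 1800 nM
Compound 3, `O=S(=O)(NCCCNCc1ccccc1Cl)c1cc(C(F)(F)F)cc(C(F)(F)F)c1`: 9300 nM

Of the compounds shown here, three sharing the same core have been measured in a functional assay on A2780 cells (Homo sapiens) for inhibition, read by MTT assay, with a stated time of 72 h; a higher number here means a weaker inhibitor of growth, a lower number a stronger inhibitor of growth. Compound 3 stands at the highest number of the three: its nearest neighbour is compound 1, with a 3.0-fold higher number from compound 1 to compound 3 (0.48 log units; beyond the scatter), and its furthest is compound 2, with a 5.2-fold higher number from compound 2 to compound 3 (0.71 log units; beyond the scatter). Between compound 1 and compound 2 the difference is a 1.7-fold lower number from compound 1 to compound 2 (0.24 log units; within the scatter).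

Compound 4, `O=S(=O)(NCCCNCc1ccc(Cl)c(C(F)(F)F)c1)c1cc(C(F)(F)F)cc(C(F)(F)F)c1`, has not yet been measured. It differs from compound 3 in one place: 4-chloro-3-(trifluoromethyl)phenyl in place of 2-chlorophenyl on a saturated chain carbon bound to an amine nitrogen.

Among the measured compounds shown here, the step that bears most directly on this change is the one from compound 2 to compound 3, since compound 4 again carries a 4-chlorophenyl pattern on the saturated chain carbon bound to the amine nitrogen, now with an added trifluoromethyl group. Because a 5.2-fold higher number from compound 2 to compound 3 (0.71 log units; beyond the scatter) was beyond the scatter, a drop in the number from compound 3 to compound 4 is expected, of roughly the size a 6.2-fold lower number from compound 3 to compound 4 (0.79 log units; beyond the scatter). For the measured compounds named here, the trifluoromethyl group itself has no precedent among the measured compounds, so the range is kept wide. In this assay compound 4 is estimated at 1500 nM, within 600 nM to 4000 nM.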

Compound 4, concentration for 50% growth inhibition: 5900 nM
Beside the measured number, compound 4's estimate is 3.9-fold (0.59 log units) below it; measured number outside the range, above it.
By their numbers in this assay, from the lowest: compounds 2, 1, 4 and 3 (each within the scatter of the next, the first and the last beyond it).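

In this assay, trifluoromethyl in place of hydrogen on an aromatic carbon of the 4-chlorophenyl group gives a 3.3-fold higher number from compound 2 to compound 4 (0.52 log units; beyond the scatter), so the 4-chloro pattern alone does not keep the low number of compound 2 once this group is added. The added group also removes the separation seen earlier between the 4-chloro and 2-chloro patterns, with a 1.6-fold lower number from compound 3 to compound 4 (0.20 log units; within the scatter), and the position tolerates this larger group about as well as naphthalen-1-yl, with a 1.9-fold higher number from compound 1 to compound 4 (0.28 log units; within the scatter). Nothing measured here accounts for the step caused by the trifluoromethyl group. The compounds shown leave open whether a methyl group or a nitrile in the place of the trifluoromethyl would give the same step from compound 2. They also leave open where 3-(trifluoromethyl)phenyl, without the chlorine, would stand.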